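The source may report more compounds than this note shows. Statements on the series, on what has been measured and on what is new or still open speak of the compounds shown alone.

Compound 2, `COc1cc(NC(=O)Nc2cc(Nc3cc(Br)ccc3OC)ncn2)cc(OC)c1`, gives 76.3% in a functional assay on HCC827 cells (Homo sapiens) for inhibition, read by MTT assay, with a stated time of 48 h, tested at 10 uM (on this read-out higher numbers stand for more inhibition at the one concentration tested (going by the name of the read-out) and lower numbers for less inhibition), and among the three measured compounds it stands highest on the numbers, though its gap to compound 3 lies within the scatter. Compound 3, `COc1cc(Nc2cc(NC(=O)Nc3c(Cl)cccc3Cl)ncn2)cc(OC)c1`, gives 73.7%, while compound 1, `COc1ccc(Br)cc1Nc1cc(NC(=O)Nc2c(Cl)cccc2Cl)ncn1`, gives 53%. Going by the values given here, the only single-change step measured so far runs a number 23.3 percentage points higher from compound 1 to compound 2 (beyond the scatter), and it concerns the aryl group on the urea nitrogen, not the part of the molecule that changes here.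

Compound 4, `COc1cc(NC(=O)Nc2cc(Nc3cccc(C(C)(C)C)c3)ncn2)cc(OC)c1`, differs from compound 2 in that (3-(tert-butyl)phenyl in place of 5-bromo-2-methoxyphenyl on a nitrogen on an aromatic ring). Among the compounds with values here, no measured step touches this nitrogen, so there is no direct precedent for the size or direction of the step. Compounds 2 and 3 carry different aryl groups on that nitrogen and show numbers that lie within the scatter of each other, but the two compounds also differ elsewhere, so nothing firm follows from them.

With that in mind, the step from compound 2 to compound 4 is expected to be small, a number 11.3 percentage points lower from compound 2 to compound 4 (beyond the scatter), possibly a modest drop. The estimate for compound 4 is therefore 65%, with a range from 40% to 85%.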

Compound 4, a percentage reported as inhibition, at one concentration (the size of the read-out at that concentration, not a potency): 48.7%
Compound 4: middle estimate off by 16.3 percentage points, on the high side; measured number inside the range.
By their numbers in this assay, from the lowest: compounds 4 and 1 (each within the scatter of the next); then compounds 3 and 2 (each within the scatter of the next).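

In this assay, placing 3-(tert-butyl)phenyl in place of 5-bromo-2-methoxyphenyl on a nitrogen on an aromatic ring gives a number 27.6 percentage points lower from compound 2 to compound 4 (beyond the scatter), the first measured sign that the aryl group on this nitrogen bears on the read-out while 3,5-dimethoxyphenyl stays on the urea. The change exchanges a group holding oxygen, bromine and one hydrogen-bond acceptor for an all-carbon group with no hydrogen-bond acceptor, so this single pair cannot separate the part played by each of these differences. Nothing measured here accounts for the size or direction of this step.

Still open, as far as these compounds go, is whether the bromine, the methoxy group or the tert-butyl group itself governs the step, and whether the same exchange would read alike with 2,6-dichlorophenyl on the urea. The compounds shown also leave open how this position would respond to an aryl group carrying a morpholine or a carboxylic acid, or to a plain unsubstituted phenyl.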